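Pyridin-3-yl for 3-methylphenyl on the cyclopropane of compound 3

This account rests on a few compounds, and the source may have more. Where it says the series, first, only, none or still open, it means among the compounds named here.

The series shares one core, an amide of a 2-arylcyclopropane carboxylic acid on a biphenylamine nitrogen carrying a saturated chain. Compound 1 `CC(C)CCCN(C(=O)[C@@H]1C[C@H]1c1ccccc1)c1ccc(-c2ccccc2)cc1` gives in a functional assay for agonist activity at G protein-coupled receptor 88 (Homo sapiens), read by HTRF and cAMP accumulation (a lower number here means that less compound is needed, a higher number that more compound is needed for the effect), only a limit, > 100 nM, at which one of the three results shown sits (the limit of > 100 nM in this assay, at which 1 of the 3 values shown sits). Going by the values given here, compound 2 `O=C([C@@H]1C[C@H]1c1ccccc1)N(CCNCC1CCCCC1)c1ccc(-c2ccccc2)cc1` gives 6.6 nM in this assay, and the one step measured between compounds, an at least 15-fold lower number from compound 1 to compound 2 (1.18 log units; beyond the scatter), comes from (cyclohexylmethyl)amino in place of isobutyl on the chain. Compound 3 `CC[C@H](C)[C@H](N)CN(C(=O)[C@@H]1C[C@H]1c1cccc(C)c1)c1ccc(-c2ccccc2)cc1` gives 1200 nM in this assay, the highest of the two numbers measured, the nearest being compound 2 with 6.6 nM.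

Compound 4 `CC[C@H](C)[C@H](N)CN(C(=O)[C@@H]1C[C@H]1c1cccnc1)c1ccc(-c2ccccc2)cc1` differs from compound 3 in pyridin-3-yl in place of 3-methylphenyl on a saturated ring carbon. Among the compounds with values here, no measured step touches the aromatic ring on the saturated ring carbon; the only measured step concerns the chain, so nothing here speaks directly to this change. The expected step is therefore a 1.7-fold higher number from compound 3 to compound 4 (0.22 log units; within the scatter), not confidently beyond the scatter. For compound 4 the expected value in this assay is 2000 nM, with a range from 600 nM to 6500 nM.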

Compound 4, half-maximal effective concentration: 1500 nM
Estimate against measurement, compound 4: 1.3-fold (0.12 log units) above; the measured number falls inside the stated range.
By their numbers in this assay, from the lowest: compound 2; then compounds 3 and 4 (each within the scatter of the next).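

In this assay, going by these compounds alone, this is the first reading on the aromatic ring at the cyclopropane; the only earlier step concerned the chain. Pyridin-3-yl in place of 3-methylphenyl on a saturated ring carbon gives a 1.3-fold higher number from compound 3 to compound 4 (0.10 log units; within the scatter), so with the chain of compound 3 this position tolerates the exchange of a carbon-only ring bearing a methyl for a ring with one nitrogen and one hydrogen-bond acceptor, without a difference that can be told from the scatter. Nothing shown gives a measured reason for this result.

From the compounds shown here alone, both compounds carry the same amino-substituted chain and sit far from compound 2, so whether the exchange would read the same on the (cyclohexylmethyl)amino chain remains open. Also open, going by these compounds, is how this position responds to other groups, such as pyridin-2-yl, pyridin-4-yl, a fluorophenyl ring or a phenyl ring bearing a carboxylic acid, since a single exchange on one chain does not describe the range of groups allowed here.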